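Lengthening the nitrile chain on the aromatic nitrogen

The source may report more compounds than this note shows. Statements on the series, on what has been measured and on what is new or still open speak of the compounds shown alone.

Measured so far:
compound 1, `Cc1nc2c(Br)c(Br)c(Br)c(Br)c2n1CC#N`: 52%
compound 2, `Cc1nc2c(Br)c(Br)c(Br)c(Br)c2n1CCC#N`: 85%

Both numbers come from a functional assay on MCF7 cells (Homo sapiens) for cytotoxicity, read by MTT assay, with a stated time of 24 h, tested at 10 uM; a higher number here means a weaker effect of the compound at the concentration tested, a lower number a stronger effect. Among the measured compounds shown here, compound 2 stands highest of the two, with compound 1 as its only neighbour, the step of a number 33 percentage points higher from compound 1 to compound 2 (beyond the scatter) lying beyond the scatter. Compound 3, `Cc1nc2c(Br)c(Br)c(Br)c(Br)c2n1CCCC#N`, is not yet measured. It differs from compound 2 by cyanomethyl in place of cyano on a saturated chain carbon, two bonds along the chain from an aromatic nitrogen. For the measured compounds named here, the one step that bears on it is the same kind of lengthening, one bond closer to the aromatic nitrogen: from compound 1 to compound 2 the number rose by a large margin, a number 33 percentage points higher from compound 1 to compound 2 (beyond the scatter). For compound 3 a further rise in this assay is therefore expected, though a smaller one, since compound 2 already sits close to the point at which the assay reads no effect; the expected step is a number 7 percentage points higher from compound 2 to compound 3 (within the scatter). The estimate for compound 3 in this assay is 92%, with a range from 78% to 104%.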

Compound 3, a percentage reported as activity, at one concentration (the size of the read-out at that concentration, not a potency): 65%
For compound 3 the middle estimate is 27 percentage points above the measured one, and the stated range ends above it.
By their numbers in this assay, from the lowest: compound 1; then compound 3; then compound 2.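

In this assay, the effect of lengthening the chain on the aromatic nitrogen does not run in one direction: the rise from cyanomethyl to 2-cyanoethyl reverses on going on to 3-cyanopropyl, with a number 20 percentage points lower from compound 2 to compound 3 (beyond the scatter). The reversal is only partial, since the comparison of the two ends of the series gives a number 13 percentage points higher from compound 1 to compound 3 (beyond the scatter), which leaves compound 1 with the lowest number of the three, and its steps to both others lie beyond the scatter. Nothing available bears on why the same one-carbon change raises the number at one chain length and lowers it at the next.

As far as these compounds go, whether a longer chain would lower the number further or raise it again remains open. So does whether the trend depends on the nitrile, as a carboxylic acid or an amine at the chain end could show.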